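The compounds below may be only part of what the source reports. "The series", "measured", "known", "first", "only" and "open" are said of these compounds alone.

In a functional assay on PC-3 cells (Homo sapiens) for cytotoxicity, read by sulforhodamine B assay, with a stated time of 48 h (a lower number here means a stronger inhibitor, a higher number a weaker inhibitor), compound 1, with the structure `C=CCOc1cc(Br)ccc1C(=O)c1cccnc1`, gives > 100000 nM, which is a limit of the assay rather than a number. For the measured compounds named here, compound 2, with the structure `C=CCOc1c(Cl)cccc1C(=O)c1cccnc1`, is the only other compound with a value in this assay and also gives > 100000 nM, again a limit. Compound 1 thus stands at the edge of what the assay reports, on (the limit of > 100000 nM in this assay, at which 2 of the 2 values shown sit). No step between two measured compounds is available, so the size of a change cannot be read from the numbers shown. The step taken here leads to compound 3, with the structure `O=C(c1cccnc1)c1ccc(Br)cc1O`: the change from compound 1 is hydrogen in place of allyl on an oxygen on an aromatic ring. Going by the values given here, since compound 1 sits at the limit and no step is measured, the step of an at least 1.2-fold lower number from compound 1 to compound 3 (0.09 log units; that floor lies within the scatter) is expected to be small, with no clear direction. Compound 3 is accordingly estimated at 80000 nM, within 20000 nM to 300000 nM.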

Compound 3, half-maximal inhibitory concentration: 88600 nM
Compound 3: middle estimate off by 1.1-fold (0.04 log units), on the low side, within the range that was stated.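

In this assay compound 3 gives 88600 nM, the only value among the compounds shown that is a number rather than a limit. Allyloxy to hydroxy at this position therefore brings the reading inside what the assay reports, yet the step is only an at least 1.1-fold lower number from compound 1 to compound 3 (0.05 log units; that floor lies within the scatter), so the numbers do not establish that removing the allyl group changes the result at all. The reading of compound 3 also lies close to the limit that bounds the other two compounds: the limit of > 100000 nM in this assay, at which 2 of the 3 values shown sit.

From the compounds shown here alone, how far compound 1 actually lies from compound 3 remains open, as does whether compound 2 would respond in the same way to the same change. Also open, going by these compounds, is what a methyl group or a longer chain on this oxygen would give, or an amine or a carboxylic acid in place of the hydroxy group.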